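Cytotoxicity limits in the cyano anilino series

A few compounds are considered here, and "the series" means these few. Any claim that something is new, unique, unknown or untested is made for them only; others in the source may bear on it.

Compound 1 `N#Cc1ccc(Nc2nccc(OCC(=O)Nc3ccc(F)cc3)n2)cc1` gives > 344000 nM (a limit)
Compound 2 `N#Cc1ccc(NC(=O)COc2ccnc(Nc3ccc(C#N)cc3)n2)cc1` gives > 337000 nM (a limit)
Compound 3 `Cc1cc(OCC(=O)Nc2ccc(F)cc2)nc(Nc2ccc(C#N)cc2)n1` gives > 331000 nM (a limit)

In an ADME assay on MT4 cells (Homo sapiens) for cytotoxicity, read by MTT assay, with a stated time of 5 days (on this read-out lower numbers stand for higher toxicity in this test and higher numbers for lower toxicity in this test), compound 3 gives only a limit, > 331000 nM and no number, and the other two readings are limits as well. Compound 4 `Cc1cc(OCC(=O)Nc2cccc(Cl)c2)nc(Nc2ccc(C#N)cc2)n1` has 3-chlorophenyl in place of 4-fluorophenyl on an amide-type nitrogen with the rest of compound 3 unchanged. Neither a step that the two limits leave unreadable from compound 1 to compound 2 with cyano in place of fluoro on an aromatic carbon nor a step that the two limits leave unreadable from compound 1 to compound 3 with methyl in place of hydrogen on an aromatic carbon gives a size to carry over, so no step beyond the scatter and no direction is expected in this assay here. The expected outcome is an at least 1.1-fold lower number from compound 3 to compound 4 (0.04 log units; that floor lies within the scatter) and it may again be only a limit. For compound 4 the estimate is 300000 nM with an expected range of 80000 nM to 340000 nM in this reading.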

Compound 4, half-maximal cytotoxic concentration: 32200 nM
Beside the measured number, compound 4's estimate is 9.3-fold (0.97 log units) above it; the whole stated range lies above it.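

In this assay, 3-chlorophenyl in place of 4-fluorophenyl on an amide-type nitrogen gives an at least 10-fold lower number from compound 3 to compound 4 (1.01 log units; beyond the scatter). For the compounds shown here, the earlier steps cannot be read, so this is the first change with a size, and compound 4 is the first compound with a number rather than a limit. Nothing shown accounts for the size of this step.

Going by these compounds, whether the step follows from the chlorine or from its place on the ring remains open. A 4-chlorophenyl group on the same amide-type nitrogen would separate the two.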